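The source may report more compounds than this note shows. Statements on the series, on what has been measured and on what is new or still open speak of the compounds shown alone.

Within the data shown here, in a functional assay on P388 cells (Mus musculus) for antiproliferative activity, read by colorimetric assay and MTT assay (a lower number here means a stronger inhibitor, a higher number a weaker inhibitor), compound 2 (`COc1ccc(S(=O)(=O)Nc2cccc3cc(O)[nH]c23)cc1`) gives 0.11 ug/mL, the lowest number so far. Compound 1 (`COc1ccc(S(=O)(=O)Nc2cccc3cc[nH]c23)cc1`) gives 1.1 ug/mL, and compound 3 (`O=S(=O)(Nc1ccc(Cl)c2cc[nH]c12)c1ccc(Cl)cc1`) gives 4.6 ug/mL. Compound 4 (`O=S(=O)(Nc1cccc2cc(O)[nH]c12)c1ccc(Cl)cc1`) changes compound 2 in one place: chloro in place of methoxy on an aromatic carbon. Among the measured compounds shown here, the single measured step, a 10-fold lower number from compound 1 to compound 2 (1.00 log units; beyond the scatter), is the gain on adding hydroxy, and compound 4 keeps that hydroxy. For the measured compounds named here, no measured step isolates the swap itself. Compound 3 carries chloro on that ring but also differs elsewhere, so its number, higher than that of compound 1, is only a weak hint. An expected 2.3-fold higher number from compound 2 to compound 4 (0.36 log units; beyond the scatter) is therefore small, towards a higher number. For compound 4 the estimate is 0.25 ug/mL, with an expected range of 0.07 ug/mL to 0.9 ug/mL.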

Compound 4, half-maximal inhibitory concentration: 2.2 ug/mL
Estimate against measurement, compound 4: 8.8-fold (0.94 log units) below, and the stated range ends below it.
By their numbers in this assay, from the lowest: compound 2; then compounds 1 and 4 (each within the scatter of the next); then compound 3.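

On the aromatic carbon para to a large group, the two groups are far from interchangeable in this assay: chloro in place of methoxy gives a 20-fold higher number from compound 2 to compound 4 (1.30 log units; beyond the scatter), a large step and the first measured at this position. The hydroxy is kept in compound 4, so that group alone does not hold the low number of compound 2. No measurement available here accounts for the size of this step.

As far as these compounds go, whether an amine or an ethoxy group at this position would hold the number of compound 2 stays open. Also open, from the compounds shown here alone, is whether the same swap has a step of this size on the core of compound 1, without the hydroxy.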